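The compounds below may be only part of what the source reports. "The series", "measured", "known", "first", "only" and "open" are said of these compounds alone.

Measured compounds:
compound 1 `CC(C)(C)OC(=O)N1CCN(CC(O)Cn2nc(-c3ccc(Cl)c(C#Cc4ccc(Cl)cc4)c3)c3c2CCN(S(C)(=O)=O)C3)CC1` — > 10000 nM
compound 2 `COC(=O)C1CCN(CC(O)Cn2nc(-c3ccc(Cl)c(C#Cc4ccc(Cl)cc4)c3)c3c2CCN(S(C)(=O)=O)C3)CC1` — > 10000 nM
compound 3 `CS(=O)(=O)N1CCc2c(c(-c3ccc(Cl)c(C#Cc4ccc(Cl)cc4)c3)nn2C[C@@H](O)CN2CCC(C3CCNCC3)CC2)C1` — 200 nM

In an assay on JY cells for inhibition of cathepsin S (Homo sapiens), read by Western blot (a lower number here means a stronger inhibitor, a higher number a weaker inhibitor), compound 1 reaches only a limit of the assay, > 10000 nM. Compound 2 likewise reaches only a limit in this assay, > 10000 nM. Among the measured compounds shown here, compound 3 is the one compound of the three for which this assay gives a number, 200 nM; the other two sit at the limit of > 10000 nM in this assay, at which 2 of the 3 values shown sit, so no measured step can be read between any pair of them.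

Compound 4 `CN1CCC(C2CCN(C[C@H](O)Cn3nc(-c4ccc(Cl)c(C#Cc5ccc(Cl)cc5)c4)c4c3CCN(S(C)(=O)=O)C4)CC2)CC1` has not been measured. It differs from compound 3 by methyl in place of hydrogen on an amine nitrogen in a ring. For the measured compounds named here, with no measured step to lean on, no change beyond the usual scatter is expected here. Compound 4 is therefore expected at about 200 nM in this assay, between 60 nM and 700 nM, which would be a step of no change at the digits printed from compound 3 to compound 4 (within the scatter).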

Compound 4, half-maximal inhibitory concentration: 720 nM
Beside the measured number, compound 4's estimate is 3.6-fold (0.56 log units) below it; the whole stated range lies below it.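

In this assay, the change from piperidin-4-yl to 1-methylpiperidin-4-yl brings a 3.6-fold higher number from compound 3 to compound 4 (0.56 log units; beyond the scatter). Among the compounds shown here, this is the first step that can be read, and it shows that a single added carbon on this amine nitrogen is enough to move the number beyond the scatter, though only modestly. Steps to the other two compounds cannot be read: the limit of > 10000 nM in this assay, at which 2 of the 4 values shown sit. Nothing shown gives a reason for this step. Still open, from the compounds shown here alone, is how an ethyl or acetyl group on this nitrogen would read, and whether an oxygen in place of this ring nitrogen would hold the number.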